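From 3,4-dichlorophenyl to thiophen-3-yl on a shared core

This account rests on a few compounds, and the source may have more. Where it says the series, first, only, none or still open, it means among the compounds named here.

- Compound 1 `COc1cc(C(=O)c2sc(-c3cccc([N+](=O)[O-])c3)cc2N)cc(OC)c1OC`: 11 nM
- Compound 2 `COc1cc(C(=O)c2sc(-c3ccc(Cl)c(Cl)c3)cc2N)cc(OC)c1OC`: 260 nM

In a functional assay on L1210 cells (Mus musculus) for antiproliferative activity (a lower number here means a stronger inhibitor, a higher number a weaker inhibitor), compound 2 has the higher of the two numbers, so it is the weaker inhibitor of this pair. Compound 3 `COc1cc(C(=O)c2sc(-c3ccsc3)cc2N)cc(OC)c1OC` keeps the shared core and differs from compound 2 in one place: thiophen-3-yl in place of 3,4-dichlorophenyl on an aromatic carbon. For the measured compounds named here, only one measured step bears on this change, a 24-fold higher number from compound 1 to compound 2 (1.37 log units; beyond the scatter), and it is large. It involves the same place but neither the group entering here nor any other five-membered ring, so it offers limited guidance. Going by the values given here, compound 1, at 11 nM, shows only that a much lower number is possible with a different group there. A partial move in that direction is therefore expected, smaller than the measured step. In this assay, the expected change is a 4.3-fold lower number from compound 2 to compound 3 (0.64 log units; beyond the scatter). The estimated value for compound 3 is 60 nM, with an expected range from 12 nM to 300 nM.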

Compound 3, half-maximal inhibitory concentration: 12 nM
Compound 3: the middle estimate sits 5.0-fold (0.70 log units) above what was measured; measured number inside the range.
By their numbers in this assay, from the lowest: compounds 1 and 3 (each within the scatter of the next); then compound 2.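

In this assay, thiophen-3-yl in place of 3,4-dichlorophenyl gives a 22-fold lower number from compound 2 to compound 3 (1.34 log units; beyond the scatter) here, so this place next to the ring sulfur accepts a five-membered aromatic ring with 1 sulfur, and the smaller group brings the number back to the level of compound 1. For the compounds shown here, the step of a 1.1-fold higher number from compound 1 to compound 3 (0.04 log units; within the scatter) puts these two groups level, which shows that a six-membered ring is not needed here and leaves 3,4-dichlorophenyl as the one group of the three that stands apart. No measurement shown gives a reason for this difference.

The compounds shown leave open whether furan-3-yl or an unsubstituted phenyl would stay at the level of compound 3 at this place. They also leave open whether a phenyl ring bearing a single chlorine would fall with compound 2 or with compound 1.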